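Swapping the hydroxyethyl side chain for a thioether chain

This account rests on a few compounds, and the source may have more. Where it says the series, first, only, none or still open, it means among the compounds named here.

The series shares one core, shown for compound 1 as `C[C@@H](O)[C@H](NC(=O)CN(c1nc(Cl)nc2[nH]cnc12)C1CC1)C(=O)OCc1ccccc1`. In a functional assay on the whole organism (Tail, strain ICR) with Mus musculus as the target, in the tail flick test, with a stated time of 120 min, at a dose of 25 umol/kg by the oral route (on this read-out lower numbers stand for a weaker effect and higher numbers for a stronger effect at the one dose given), compound 1 gives 30.7%, the second highest of the three numbers. Compound 2 `C[C@@H](O)[C@H](NC(=O)CN(c1nc(Cl)nc2[nH]cnc12)C1CC1)C(=O)O` gives 37.6%, and compound 3 `CC(C)[C@H](NC(=O)CN(c1nc(Cl)nc2[nH]cnc12)C1CC1)C(=O)O` gives 17.1%. The step of a number 6.9 percentage points higher from compound 1 to compound 2 (within the scatter) involved hydrogen in place of benzyl on an oxygen next to a carbonyl group. The step of a number 20.5 percentage points lower from compound 2 to compound 3 (beyond the scatter) involved isopropyl in place of 1-hydroxyethyl on a saturated chain carbon bound to an amide-type nitrogen and a carbonyl carbon.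

Compound 4 `CSCC[C@H](NC(=O)CN(c1nc(Cl)nc2[nH]cnc12)C1CC1)C(=O)OCc1ccccc1` differs from compound 1 by 2-(methylsulfanyl)ethyl in place of 1-hydroxyethyl on a saturated chain carbon bound to an amide-type nitrogen and a carbonyl carbon. The change at the same place, from compound 2 to compound 3, bears on it, because a number 20.5 percentage points lower from compound 2 to compound 3 (beyond the scatter) was a modest drop. A similar drop is therefore expected for compound 4, estimated at a number 15.7 percentage points lower from compound 1 to compound 4 (beyond the scatter). Compound 4 is expected to give 15%, within the range 0% to 32%.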

Compound 4, a percentage reported as activity, at one dose (the size of the read-out at that dose, not a potency): 31.6%
Compound 4: middle estimate off by 16.6 percentage points, on the low side; the range from low to high includes it.
By their numbers in this assay, from the lowest: compound 3; then compounds 1, 4 and 2 (each within the scatter of the next).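

In this assay, the step of a number 0.9 percentage points higher from compound 1 to compound 4 (within the scatter) shows that, with the benzyl ester in place, 2-(methylsulfanyl)ethyl can stand in for 1-hydroxyethyl on this carbon, although it has no hydrogen-bond donor. The drop seen at the same place, a number 20.5 percentage points lower from compound 2 to compound 3 (beyond the scatter), therefore does not extend to every replacement of 1-hydroxyethyl. No measurement given here explains this difference. Going by these compounds, it remains open whether a carboxylic acid in place of the benzyl ester would give the same read-out alongside the 2-(methylsulfanyl)ethyl chain. On these data alone, how an amine or a longer chain would behave at this place also remains open.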